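From Piperidin-1-yl to (Dimethylamino)methyl on the Chain

This account rests on a few compounds, and the source may have more. Where it says the series, first, only, none or still open, it means among the compounds named here.

Compound 3 `O=C1c2c[n+]([O-])c3ccccc3c2C(=O)c2c1c1ccccc1n2CCCCN1CCCCC1` gives 150 nM in a functional assay on A549 cells (Homo sapiens) for cytotoxicity, read by MTT assay, with a stated time of 72 h (on this read-out lower numbers stand for stronger inhibition and higher numbers for weaker inhibition), the second highest of the three numbers measured. Its nearest neighbour is compound 1 `CC1(C)OCC(Cn2cc(Cn3c4c(c5ccccc53)C(=O)c3c[n+]([O-])c5ccccc5c3C4=O)nn2)O1`, which in this assay gives 80 nM, while compound 2 `O=C1c2c[n+]([O-])c3ccccc3c2C(=O)c2c1c1ccccc1n2Cc1cn([C@H]2O[C@H](CO)[C@@H](O)[C@H]2O)nn1` gives 2680 nM in this assay. Within the data shown here, the only measured step, a 34-fold higher number from compound 1 to compound 2 (1.53 log units; beyond the scatter), concerns an exchange on an aromatic nitrogen and offers no guide to a change along a saturated chain. Compound 4 `CN(C)CCCCCn1c2c(c3ccccc31)C(=O)c1c[n+]([O-])c3ccccc3c1C2=O` differs from compound 3 by (dimethylamino)methyl in place of piperidin-1-yl on a saturated chain carbon, four bonds along the chain from an aromatic nitrogen. Among the measured compounds shown here, since no measured step bears on this exchange, no shift beyond the scatter is expected in this assay. Compound 4 is therefore estimated at 150 nM in this assay, within a range of 70 nM to 350 nM, which amounts to an expected step of no change at the digits printed from compound 3 to compound 4 (within the scatter).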

Compound 4, half-maximal inhibitory concentration: 210 nM
Compound 4: the middle estimate sits 1.4-fold (0.15 log units) below what was measured; the measured number falls inside the stated range.
By their numbers in this assay, from the lowest: compounds 1, 3 and 4 (each within the scatter of the next, the first and the last beyond it); then compound 2.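

In this assay, the exchange of piperidin-1-yl for (dimethylamino)methyl on a saturated chain carbon, four bonds along the chain from an aromatic nitrogen, gives a 1.4-fold higher number from compound 3 to compound 4 (0.15 log units; within the scatter) and so does not move the number beyond the scatter. Among these compounds, for this pair, the six-membered ring of the leaving group is therefore not needed to keep the number within the scatter at this place, something no earlier step could show. Nothing given here accounts for this result. As far as these compounds go, whether a morpholin-4-yl group or a primary amine would behave the same way at this place remains open. So does the effect of a shorter or longer chain, or of a carboxylic acid in place of the amine.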